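A few compounds are considered here, and "the series" means these few. Any claim that something is new, unique, unknown or untested is made for them only; others in the source may bear on it.

Compound 1 `CCCc1nc2c(C)cc(-c3nc4ccccc4n3C)cc2n1S(=O)(=O)c1ccccc1` stands at a limit in a functional assay on HCT-116 cells (Homo sapiens) for cytotoxicity, read by MTT assay; a higher number here means a weaker inhibitor, a lower number a stronger inhibitor: in this assay compound 1 gives > 50000 nM, which is a limit of the assay rather than a number. Compound 2 `CCCc1nc2c(C)cc(-c3nc4ccccc4n3C)cc2n1S(=O)(=O)c1ccc(OC)cc1` carries a methoxy group on the same sulfonyl-bearing ring, and in this assay compound 2 gives 19100 nM, an at least 2.6-fold lower number from compound 1 to compound 2 (0.41 log units; beyond the scatter). Compound 3 `CCCc1nc2c(C)cc(-c3nc4ccccc4n3C)cc2n1S(=O)(=O)c1ccc(Cl)cc1` differs from compound 1 by chloro in place of hydrogen on an aromatic carbon. Within the data shown here, the only measured step that bears on this change is the methoxy step, which also placed a group on an aromatic carbon para to a large group, so a step of similar, modest size toward a lower number is expected. Compound 3 is therefore estimated at 25000 nM, within a range from 8000 nM to 80000 nM. The expected step is an at least 2.0-fold lower number from compound 1 to compound 3 (0.30 log units; that floor lies within the scatter).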

Compound 3, half-maximal inhibitory concentration: 36800 nM
Beside the measured number, compound 3's estimate is 1.5-fold (0.17 log units) below it; the measured number falls inside the stated range.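

Like methoxy, chloro on this aromatic carbon, para to a large group, gives a value that can be read as a number in this assay: the change from hydrogen gives an at least 1.3-fold lower number from compound 1 to compound 3 (0.13 log units; that floor lies within the scatter). Going by these compounds, that step is only a floor, and its true size stays unknown because compound 1 stands at a limit of the assay: the limit of > 50000 nM in this assay, at which 1 of the 3 values shown sits. Chloro in place of methoxy gives a 1.9-fold higher number from compound 2 to compound 3 (0.28 log units; within the scatter), so these two groups cannot be told apart here.

Still open, on these data alone, is how an amine or a carboxylic acid on this carbon would read in this assay.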